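The source may hold more compounds than are shown below. What is called first, only, known or untested is meant among the compounds shown, and "the series" means these compounds.

Three compounds with a shared core were tested in an assay on isolated protein for inhibition of Dihydrofolate reductase (Homo sapiens), read by spectrophotometry, using NADPH, with stated times of 5 s and 6 min, tested at 5 uM (a higher number here means a stronger effect of the compound at the concentration tested, a lower number a weaker effect), and a fourth awaits the same test.

Compound 1 `NC1=NC2(CCOCC2)N(OCCCOc2ccc(Cl)cc2)C(N)=N1` reaches the limit of this assay, reported as > 90%, so no number is available for it. Compound 2 `NC1=NC2(CCOCC2)N(OCCCOc2cccc(Br)c2)C(N)=N1` gives 86.7% in this assay. Compound 3 `NC1=NC2(CCSCC2)N(OCCCOc2cccc(Br)c2)C(N)=N1` gives 84.2% in this assay, a reading that lies within the usual scatter of the value for compound 2; the difference between the cores of compound 2 and compound 3 is not broken down here.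

Between compound 2 and compound 1 the change is 4-chlorophenyl in place of 3-bromophenyl on an oxygen on a saturated carbon. Within the data shown here, that change carried the reading a number at least 3.3 percentage points higher from compound 2 to compound 1 (that floor lies within the scatter), a floor that rests on (the limit of > 90% in this assay, at which 1 of the 3 values shown sits), and so tells only that the value did not fall.

Compound 4 `NC1=NC2(CCSCC2)N(OCCCOc2ccc(Cl)cc2)C(N)=N1` has not yet been measured in this assay. It differs from compound 3 by 4-chlorophenyl in place of 3-bromophenyl on an oxygen on a saturated carbon, the same change as that from compound 2 to compound 1, at a place described in the same words. Compound 4 is therefore expected to show a step of about a number 3.8 percentage points higher from compound 3 to compound 4 (within the scatter) from compound 3, an expectation that rests on the value of compound 3, 84.2%, and on the reading a number at least 3.3 percentage points higher from compound 2 to compound 1 (that floor lies within the scatter). On that basis compound 4 is estimated at 88% in this assay, most likely between 80% and 93%, with a fair chance that only the limit is reported.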

Compound 4, a percentage reported as inhibition, at one concentration (the size of the read-out at that concentration, not a potency): > 90%
Compound 4 ended at the assay's limit; the forecaster's own chance of this, stated with the estimate: 35%; middle value at least 2 percentage points away from the limit.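

In this assay compound 4 gives > 90%, a limit of the assay and not a number. Carried from the core of compound 2 to the core of compound 3, 4-chlorophenyl in place of 3-bromophenyl gave a number at least 5.8 percentage points higher from compound 3 to compound 4 (that floor lies within the scatter), so on neither core did the reading drop with this change, though neither step is shown to lie beyond the scatter. This supports only the modest statement that the change was tolerated on both cores, and it does not show that the change has the same size on each, since the two steps cannot be set against each other as numbers: the same change on two cores in this assay, a number at least 3.3 percentage points higher (that floor lies within the scatter) from compound 2 to compound 1 and a number at least 5.8 percentage points higher (that floor lies within the scatter) from compound 3 to compound 4; the limit leaves it open whether they differ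

The compounds shown leave open how far the 4-chlorophenyl compounds truly stand from their 3-bromophenyl partners, as the read-out offers little room at its upper end: the limit of > 90% in this assay, at which 2 of the 4 values shown sit. They also leave open how the reading would respond if an amine or a carboxylic acid were carried on the aromatic ring, or if a longer chain took the place of the one that bears the phenoxy group.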